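This account rests on a few compounds, and the source may have more. Where it says the series, first, only, none or still open, it means among the compounds named here.

Measured in a functional assay on LoVo cells (Homo sapiens) for inhibition, read by MTT assay, with a stated time of 24 h; a higher number here means a weaker inhibitor, a lower number a stronger inhibitor:
- compound 1 `CC1(C)[C@H]2CC[C@]1(C)N(Cc1cn(-c3ccc(O)cc3)nn1)C(=O)C2`: 410 nM
- compound 2 `CC1(C)[C@H]2CC[C@]1(C)N(Cc1cn(-c3ccccc3O)nn1)C(=O)C2`: 540 nM
- compound 3 `CC1(C)[C@H]2CC[C@]1(C)N(Cc1cn(-c3cccc(Br)c3)nn1)C(=O)C2`: 30 nM

Compound 3 has the lowest number of the three, which makes it the strongest inhibitor in this small set. The gap to each of the others lies beyond the usual scatter: a 14-fold lower number from compound 1 to compound 3 (1.14 log units; beyond the scatter) and an 18-fold lower number from compound 2 to compound 3 (1.26 log units; beyond the scatter). Moving the hydroxy group around the ring makes no clear difference, with a 1.3-fold higher number from compound 1 to compound 2 (0.12 log units; within the scatter).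

Compound 4 `COc1cccc(-n2cc(CN3C(=O)C[C@@H]4CC[C@@]3(C)C4(C)C)nn2)c1` keeps the shared core and carries methoxy in place of bromo on an aromatic carbon, meta to a large group: methoxy in place of bromo on an aromatic carbon. Among the compounds with values here, no measured compound carries methoxy, and no measured step makes this exact swap, so the evidence is indirect. The closest guide is that both hydroxyphenyl compounds, which also have an oxygen-bearing group on the ring, sit well above compound 3: compound 1 at 410 nM and compound 2 at 540 nM.

A rise in the number is therefore expected in this assay, meaning weaker inhibition, though probably a smaller rise than those two large steps. The expected change is a 4.0-fold higher number from compound 3 to compound 4 (0.60 log units; beyond the scatter). For compound 4 the estimated value is 120 nM, with an expected range from 35 nM to 400 nM.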

Compound 4, half-maximal inhibitory concentration: 80 nM
Compound 4: the middle estimate sits 1.5-fold (0.18 log units) above what was measured; the range from low to high includes it.
By their numbers in this assay, from the lowest: compound 3; then compound 4; then compounds 1 and 2 (each within the scatter of the next).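

Swapping bromo for methoxy at this position, meta to a large group, costs some strength in this assay (a 2.7-fold higher number from compound 3 to compound 4 (0.43 log units; beyond the scatter)), so compound 3 remains the strongest of the four. The change also shows that an oxygen-bearing group on the ring need not bring the number up to the level of the hydroxyphenyl compounds: the number still falls on going to the methoxy compound from either one (a 5.1-fold lower number from compound 1 to compound 4 (0.71 log units; beyond the scatter); a 6.8-fold lower number from compound 2 to compound 4 (0.83 log units; beyond the scatter)), although each of these two steps changes both the group and its place on the ring, so neither effect can be separated from the other. Nothing measured alongside these values accounts for the difference between bromo and methoxy.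

On these data alone, it remains open whether a hydroxy group at the position held by methoxy would give a number close to that of compound 4 or close to those of compound 1 and compound 2. The compounds shown also leave untested how an amine, a nitrile or a longer chain such as ethoxy would behave at this position.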